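A Ring Nitrogen Enters the Aromatic Ring of Compound 3

This account rests on a few compounds, and the source may have more. Where it says the series, first, only, none or still open, it means among the compounds named here.

Compound 3 `COc1cc(C(F)(F)F)cc(SC)c1C(=O)NC1(c2cccc(F)c2)CCCN(C)C1` gives 48 nM in an assay on cells for inhibition of sodium- and chloride-dependent glycine transporter 1 (Homo sapiens); a lower number here means that less compound is needed, a higher number that more compound is needed for the effect. Among the three measured compounds its number is the second highest: compound 1 `COc1cc(C(F)(F)F)cc(SC)c1C(=O)NC1(c2ccccc2)CCCN(C)C1` gives 24 nM, and the gap between them, a 2.0-fold higher number from compound 1 to compound 3 (0.30 log units; within the scatter), lies within the usual scatter of repeated measurements. Compound 2 `COc1cc(C(F)(F)F)cc(SC)c1C(=O)NC1(c2ccc(C)cc2)CCCN(C)C1` gives 230 nM, and the step of a 4.8-fold lower number from compound 2 to compound 3 (0.68 log units; beyond the scatter) is beyond that scatter.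

Compound 4 `COc1cc(C(F)(F)F)cc(SC)c1C(=O)NC1(c2ccncc2)CCCN(C)C1` differs from compound 3 in one place: pyridin-4-yl in place of 3-fluorophenyl on a saturated ring carbon. For the measured compounds named here, no measured step swaps a ring carbon for a ring nitrogen, so the guidance is indirect. The step of a 9.6-fold higher number from compound 1 to compound 2 (0.98 log units; beyond the scatter) shows that a methyl on the aromatic ring raises the number, while a 2.0-fold higher number from compound 1 to compound 3 (0.30 log units; within the scatter) shows that a fluoro on that ring changes little. Both of these alter the same ring that is now exchanged. Taken together, they suggest that changes to this ring bring at most a modest rise in the number, with compound 3 itself showing the smaller of the two effects. On that basis compound 4 is expected to give 80 nM in this assay, between 25 nM and 260 nM, so that the step of a 1.7-fold higher number from compound 3 to compound 4 (0.22 log units; within the scatter) is expected to be small and most likely a modest increase.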

Compound 4, half-maximal effective concentration: 60 nM
The estimate for compound 4 lay 1.3-fold (0.12 log units) above the measured number, within the range that was stated.
By their numbers in this assay, from the lowest: compounds 1, 3 and 4 (each within the scatter of the next, the first and the last beyond it); then compound 2.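

In this assay, the aromatic ring on the saturated ring carbon can carry a ring nitrogen: pyridin-4-yl, with its hydrogen-bond acceptor, cannot be told apart from 3-fluorophenyl (a 1.3-fold higher number from compound 3 to compound 4 (0.10 log units; within the scatter)). Against the plain phenyl of compound 1, however, the same exchange gives a small step that can be read (a 2.5-fold higher number from compound 1 to compound 4 (0.40 log units; beyond the scatter)), whereas the fluoro step from compound 1 to compound 3 stayed within the scatter. The ring nitrogen also stands well clear of the 4-methylphenyl of compound 2 (a 3.8-fold lower number from compound 2 to compound 4 (0.58 log units; beyond the scatter)), so among these four compounds only the methyl brings a large rise in the number, while the fluoro and the ring nitrogen bring little.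

Nothing available explains why these exchanges differ in size. The compounds shown also leave open whether the placing of the ring nitrogen matters, as pyridin-3-yl would test, and how this position responds to a methoxy group, an amine or a saturated ring such as piperidine in place of the aromatic ring.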